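The source may hold more compounds than are shown below. What is called first, only, known or untested is meant among the compounds shown, and "the series" means these compounds.

In an assay on cells for activation of probable G-protein coupled receptor 34 (Mus musculus), with a stated time of 1 h (a lower number here means a smaller maximal response, a higher number a larger maximal response), compound 1 `N[C@@H](COP(=O)(O)OCCCOC(=O)CCc1ccccc1OCc1cccc(Oc2ccccc2)c1)C(=O)O` gives 0.48, compound 2 `N[C@@H](COP(=O)(O)OCCCOC(=O)CCc1ccccc1OCc1cccc(Oc2ccc(Cl)cc2)c1)C(=O)O` gives 0.76, and compound 3 `CC(C)(C)c1ccc(Oc2cccc(COc3ccccc3CCC(=O)OCCCOP(=O)(O)OC[C@H](N)C(=O)O)c2)cc1` gives 0.079, the lowest of the three, with a number 0.40 lower from compound 1 to compound 3 (beyond the scatter) and a number 0.68 lower from compound 2 to compound 3 (beyond the scatter), both large. Compound 4 `Cc1ccccc1-c1ccc(Oc2cccc(COc3ccccc3CCC(=O)OCCCOP(=O)(O)OC[C@H](N)C(=O)O)c2)cc1` differs from compound 3 in one place: 2-methylphenyl in place of tert-butyl on an aromatic carbon. For the measured compounds named here, no measured step swaps the tert-butyl for an aromatic ring, so the only guide is that the tert-butyl itself lowered the response sharply in this assay, as seen in the step a number 0.40 lower from compound 1 to compound 3 (beyond the scatter). A group larger again at the same place is expected to keep the response low, so the step a number 0.021 higher from compound 3 to compound 4 (within the scatter) is estimated to stay within the scatter. Compound 4 is therefore expected to reach about 0.1, somewhere between 0.02 and 0.35.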

Compound 4, intrinsic activity: the largest response reached, as a fraction of the reference agonist's: 0.94
Compound 4: the middle estimate sits 0.84 below what was measured, and the stated range ends below it.
By their numbers in this assay, from the lowest: compound 3; then compound 1; then compound 2; then compound 4.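

At this place, on an aromatic carbon para to a large group, the count of heavy atoms does not order the response in this assay: the larger 2-methylphenyl in place of tert-butyl gives a number 0.86 higher from compound 3 to compound 4 (beyond the scatter). The same group also outdoes chloro and hydrogen, with a number 0.18 higher from compound 2 to compound 4 (beyond the scatter) and a number 0.46 higher from compound 1 to compound 4 (beyond the scatter), so a big group here can raise the response as well as lower it. Nothing given here explains the reversal.

On these data alone, what a plain phenyl or a cyclohexyl would give at this place remains open, and with it whether the ring or its methyl matters.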